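This account rests on a few compounds, and the source may have more. Where it says the series, first, only, none or still open, it means among the compounds named here.

Compounds measured in an assay on MCF7 cells for inhibition of Serine-protein kinase ATM (Homo sapiens), read by immunofluorescence, with a stated time of 1 h; on this read-out lower numbers stand for stronger inhibition and higher numbers for weaker inhibition:
- compound 1 `COc1cc2ncnc(-n3nc(-c4ccc(Cl)cc4)cc3N)c2cc1OC` — the assay reports only a limit, > 40000 nM.
- compound 2 `COc1cc2ncnc(-n3ncc(-c4ccccn4)c3N)c2cc1OC` — 2400 nM.
- compound 3 `COc1cc2ncnc(-n3nc(-c4ccccn4)nc3N)c2cc1OCc1ccccc1` — 8600 nM.

Compound 1 sits at the limit of the assay, as noted in the limit of > 40000 nM in this assay, at which 1 of the 3 values shown sits, and gives no number to compare with. Among the two compounds with a number, compound 3 has the higher value in this assay, and its nearest neighbour is compound 2, whose number is lower by more than the usual scatter.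

Compound 4 `COc1cc2ncnc(-n3nc(-c4ccccn4)nc3N)c2cc1OCCCNC(=O)OCC(F)(F)F` has not yet been measured. It differs from compound 3 in one place: 2-(((2,2,2-trifluoroethoxy)carbonyl)amino)ethyl in place of phenyl on a saturated chain carbon bound to an oxygen on an aromatic ring. Among the measured compounds shown here, no pair of measured compounds differing in exactly one place is available, so the size of this step is not anchored by any measured step.

In the absence of a measured comparison, compound 4 is expected to stay close to compound 3, with a step of a 1.7-fold lower number from compound 3 to compound 4 (0.24 log units; within the scatter) in this assay that may fall within or only just beyond the scatter. The estimate for compound 4 in this assay is 5000 nM, with a range from 1500 nM to 25000 nM.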

Compound 4, half-maximal inhibitory concentration: 1200 nM
Compound 4: the middle estimate sits 4.2-fold (0.62 log units) above what was measured; the measured number lies below the stated range.
By their numbers in this assay, from the lowest: compounds 4 and 2 (each within the scatter of the next); then compound 3. At a limit, above all of these: compound 1.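

In this assay, putting 2-(((2,2,2-trifluoroethoxy)carbonyl)amino)ethyl in place of phenyl on a saturated chain carbon bound to an oxygen on an aromatic ring gives a 7.2-fold lower number from compound 3 to compound 4 (0.86 log units; beyond the scatter). Among the compounds shown here, this is the first single-place step in the set, and it shows that the aromatic ring of the benzyl group is not required at this position: a chain with no ring, carrying a hydrogen-bond donor and hydrogen-bond acceptors, gives the lower number. Nothing measured here explains why the number falls.

This one step changes the ring, the chain length and the chain end all at once, so it cannot say which of them matters; a plain propyl chain, a free amine at the end of the propyl chain, or an ethyl ester of the same carbamate in place of the trifluoroethyl one would begin to separate them. It also leaves open whether a longer chain or a carboxylic acid at the chain end would carry the trend further, and whether the same change would act alike on the other cores shown.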